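The compounds below may be only part of what the source reports. "The series", "measured", "known", "first", "only" and "open" are said of these compounds alone.

Compound 1 `O=C1Nc2ccc(Cl)cc2/C1=N/NC(=S)N1CCN(c2ccc(Cl)cc2)CC1` gives 8180 nM and compound 2 `O=C1Nc2ccc(Cl)cc2/C1=N/NC(=S)N1CCN(c2ccc(F)cc2)CC1` gives 8900 nM in a functional assay on A549 cells (Homo sapiens) for inhibition, read by MTT assay, with a stated time of 72 h; a higher number here means a weaker inhibitor, a lower number a stronger inhibitor.

Compound 2 carries the higher of the two numbers in this assay, but the step of a 1.1-fold higher number from compound 1 to compound 2 (0.04 log units; within the scatter) shows compound 1 standing within the scatter of it. Compound 3 `O=C1Nc2ccc(Cl)cc2/C1=N/NC(=S)N1CCN(c2ccc([N+](=O)[O-])cc2)CC1` differs from compound 2 by nitro in place of fluoro on an aromatic carbon. For the measured compounds named here, the only measured step, a 1.1-fold higher number from compound 1 to compound 2 (0.04 log units; within the scatter), exchanges one halogen for another at the same place and stayed within the scatter; no measured step brings a nitro group in. Compound 3 is therefore expected to stay close to compound 2, with a step of a 1.1-fold lower number from compound 2 to compound 3 (0.05 log units; within the scatter), estimated at 8000 nM, ranging from 4000 nM to 16000 nM.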

Compound 3, half-maximal inhibitory concentration: 11800 nM
For compound 3 the middle estimate is 1.5-fold (0.17 log units) below the measured one, and the stated range covers the measured number.
By their numbers in this assay, from the lowest: compounds 1, 2 and 3 (each within the scatter of the next).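

Read in this assay, the exchange of a halogen for a nitro group gives a 1.3-fold higher number from compound 2 to compound 3 (0.12 log units; within the scatter) and a 1.4-fold higher number from compound 1 to compound 3 (0.16 log units; within the scatter), so this place on the aromatic ring, para to a large group, accepts a group with more heavy atoms and with hydrogen-bond acceptors, and the three compounds remain within the scatter of one another. Thus the earlier halogen exchange is not the only change here that stays within the scatter. No evidence is available to explain these numbers.

As far as these compounds go, whether an amine, a carboxylic acid or a longer chain at this place would also stay within the scatter remains open. So does whether changes elsewhere on the shared core would move the number further.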